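Iodo in place of chloro in a Toll-like receptor 8 inhibitor

The source may report more compounds than this note shows. Statements on the series, on what has been measured and on what is new or still open speak of the compounds shown alone.

compound 1 `O=C(Nc1ccc(Oc2cc(F)cc(C(F)(F)F)c2)cc1)c1c(F)cccc1Cl`: 1590 nM
compound 2 `O=C(Nc1ccc(Oc2cc(Cl)cc(C(F)(F)F)c2)cc1)c1c(F)cccc1Cl`: 2040 nM

In an assay on HEK293 cells for inhibition of Toll-like receptor 8 (Homo sapiens), with a stated time of 16 h (a higher number here means a weaker inhibitor, a lower number a stronger inhibitor), compound 2 stands beside compound 1, the step of a 1.3-fold higher number from compound 1 to compound 2 (0.11 log units; within the scatter) lying within the scatter. Compound 3 `O=C(Nc1ccc(Oc2cc(I)cc(C(F)(F)F)c2)cc1)c1c(F)cccc1Cl` carries iodo in place of chloro on an aromatic carbon. Going by the values given here, the only measured step that bears on this, a 1.3-fold higher number from compound 1 to compound 2 (0.11 log units; within the scatter), exchanged one halogen for another and left the number essentially unchanged; no step to iodo has been measured. Compound 3 is therefore expected to show little change in this assay, a step of a 1.2-fold higher number from compound 2 to compound 3 (0.09 log units; within the scatter). The estimate for compound 3 is 2500 nM, with a range from 1000 nM to 6500 nM.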

Compound 3, half-maximal inhibitory concentration: 5000 nM
For compound 3 the middle estimate is 2.0-fold (0.30 log units) below the measured one; low and high end bracket the measured number.
By their numbers in this assay, from the lowest: compounds 1 and 2 (each within the scatter of the next); then compound 3.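

In this assay, the halogen on this aromatic carbon, meta to a trifluoromethyl group, does matter: iodo gives a 2.5-fold higher number from compound 2 to compound 3 (0.39 log units; beyond the scatter) and a 3.1-fold higher number from compound 1 to compound 3 (0.50 log units; beyond the scatter) and so a weaker inhibitor, whereas fluoro and chloro could not be told apart. Going by these compounds alone, this is the first change at this position whose step lies beyond the scatter. No measurement shown here accounts for the step.

From the compounds shown here alone, what remains open is how groups other than halogens behave at this position. A methoxy group, a nitrile or a plain hydrogen could fall with compound 1 and compound 2 or with compound 3.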